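The source may hold more compounds than are shown below. What is called first, only, known or untested is meant among the compounds shown, and "the series" means these compounds.

Measured in a functional assay on SK-OV-3 cells (Homo sapiens) for cytotoxicity; on this read-out higher numbers stand for an effect only at larger amounts of compound and lower numbers for an effect already at smaller amounts:
compound 1 `C=CCCCCCC#CC#CCO` gives 9.79 ug/mL;
compound 2 `C=CCCCCCCCC#CC#CC(O)CC(C)=O` gives 3.34 ug/mL;
compound 3 `C=CCCCCCCCC#CC#CCO` gives 3.23 ug/mL.

Compound 1 has the highest number of the three in this assay; compound 2 and compound 3 sit close to each other, a 1.0-fold lower number from compound 2 to compound 3 (0.01 log units; within the scatter), while a 3.0-fold lower number from compound 1 to compound 3 (0.48 log units; beyond the scatter). Compound 4 `C=CCCCCCC#CC#CCOCCO` differs from compound 1 by 2-hydroxyethyl in place of hydrogen on an oxygen on a saturated carbon. For the measured compounds named here, no measured step changes the oxygen on a saturated carbon itself. The nearest comparison is the step at the carbon bearing that oxygen, a 1.0-fold lower number from compound 2 to compound 3 (0.01 log units; within the scatter), which stayed within the scatter; the step from compound 1 to compound 3 concerns the chain end and is not taken as a guide. A step within the scatter is therefore expected, a 1.2-fold lower number from compound 1 to compound 4 (0.06 log units; within the scatter). Compound 4 is estimated at 8.5 ug/mL (range 3.5 ug/mL to 20 ug/mL).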

Compound 4, concentration for half-maximal effect: 17.9 ug/mL
Compound 4: the middle estimate sits 2.1-fold (0.32 log units) below what was measured, within the range that was stated.
By their numbers in this assay, from the lowest: compounds 3 and 2 (each within the scatter of the next); then compounds 1 and 4 (each within the scatter of the next).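

Placing 2-hydroxyethyl in place of hydrogen on an oxygen on a saturated carbon gives a 1.8-fold higher number from compound 1 to compound 4 (0.26 log units; within the scatter) in this assay on an atom that no earlier step had changed. The hydrogen on this oxygen can therefore be replaced by this group without a step beyond the scatter. Nothing available gives a reason for this result.

Still open, going by these compounds, is whether a longer chain on this oxygen, or an amine or a carboxylic acid in place of the terminal hydroxy group of 2-hydroxyethyl, would also stay within the scatter. Also open, on these data alone, is whether the same change on compound 3 would give a similar step.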